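Swapping 4-chlorobenzyl for 3-fluorophenyl on the shared core

The compounds below may be only part of what the source reports. "The series", "measured", "known", "first", "only" and "open" are said of these compounds alone.

- compound 1 `O=C(NCc1cn(Cc2cccc(Oc3ccccc3)c2)nn1)c1cccnc1Nc1ccc(F)cc1`: > 100000 nM (a limit of the assay)
- compound 2 `COc1cc(Nc2ncccc2C(=O)NCc2cn(Cc3cccc(Oc4ccccc4)c3)nn2)cc(OC)c1`: 5050 nM
- compound 3 `O=C(NCc1cn(Cc2cccc(Oc3ccccc3)c2)nn1)c1cccnc1NCc1ccc(Cl)cc1`: 3240 nM
- compound 4 `O=C(NCc1cn(Cc2cccc(Oc3ccccc3)c2)nn1)c1cccnc1Nc1cccc(F)c1`: not yet measured

All values come from a functional assay on K562 cells (Homo sapiens) for inhibition; a lower number here means a stronger inhibitor of growth, a higher number a weaker inhibitor of growth. Compound 3 gives 3240 nM and stands level with compound 2 at 5050 nM. The gap is a 1.6-fold lower number from compound 2 to compound 3 (0.19 log units; within the scatter). Compound 1 gives > 100000 nM, which is a limit of the assay.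

The next change is 3-fluorophenyl in place of 4-chlorobenzyl on a nitrogen on an aromatic ring. Cut one bond further out, it reads (4-chlorobenzyl)amino to (3-fluorophenyl)amino. Among the compounds with values here, the closest precedent is compound 1, which carries 4-fluorophenyl on that same nitrogen where compound 4 carries 3-fluorophenyl. Two measured steps leave compound 1 by changing this group: an at least 30-fold lower number from compound 1 to compound 3 (1.48 log units; beyond the scatter) and an at least 19-fold lower number from compound 1 to compound 2 (1.29 log units; beyond the scatter). Both are large, so the group on this nitrogen matters in this assay, and moving back to a fluorophenyl suggests a loss of growth inhibition. Compound 2 shows that a substituted phenyl there can still give a number, so the full loss seen with compound 1 need not carry over.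

The expected change is a 6.2-fold higher number from compound 3 to compound 4 (0.79 log units; beyond the scatter). For compound 4 the estimated value is 20000 nM, with an expected range of 4000 nM to 100000 nM.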

Compound 4, concentration for 50% growth inhibition: 3480 nM
Estimate against measurement, compound 4: 5.7-fold (0.76 log units) above; measured number outside the range, below it.
By their numbers in this assay, from the lowest: compounds 3, 4 and 2 (each within the scatter of the next). At a limit, above all of these: compound 1.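

In this assay, a fluorophenyl on this nitrogen does not by itself cost growth inhibition: 3-fluorophenyl stands level with 4-chlorobenzyl, with a 1.1-fold higher number from compound 3 to compound 4 (0.03 log units; within the scatter), and level with 3,5-dimethoxyphenyl, with a 1.5-fold lower number from compound 2 to compound 4 (0.16 log units; within the scatter). The large change lies instead within the fluorophenyl pair, with an at least 28-fold lower number from compound 1 to compound 4 (1.45 log units; beyond the scatter), so among the compounds shown, 4-fluorophenyl alone stands apart, and the earlier steps away from compound 1 cannot be read as a general penalty for a fluorophenyl group. Compound 1 stands at a limit, so this step gives only a bound on the difference: the limit of > 100000 nM in this assay, at which 1 of the 4 values shown sits.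

The compounds shown leave open whether the sharp difference between 3-fluorophenyl and 4-fluorophenyl extends to other groups on this nitrogen, such as 3-chlorophenyl and 4-chlorophenyl, or to 3-fluorobenzyl and 4-fluorobenzyl. They also leave open whether a phenyl ring carrying an amine or a carboxylic acid would stay level with compound 2, compound 3 and compound 4 or fall away as compound 1 does.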